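The compounds below may be only part of what the source reports. "The series", "measured", "known", "first", "only" and "open" are said of these compounds alone.

Measured so far in an assay on mitochondria from L6 cells (Rattus norvegicus) for activation, with a stated time of 90 min; on this read-out higher numbers stand for an effect only at larger amounts of compound and lower numbers for an effect already at smaller amounts:
Compound 1, `Fc1ccccc1Nc1nc2nonc2nc1NCCC(F)(F)F`, reaches only a limit, > 100000 nM.
Compound 2, `Fc1ccccc1Nc1nc2nonc2nc1NC1CCCCC1`, gives 13400 nM.
Compound 3, `Fc1ccc(Nc2nc3nonc3nc2Nc2ccccc2F)c(F)c1`, gives 300 nM.

All three share one core and differ only in the group carried on a nitrogen on an aromatic ring. Compound 3 stands lowest of the two numbers: a 45-fold lower number from compound 2 to compound 3 (1.65 log units; beyond the scatter). Compound 1 sits at the limit of > 100000 nM in this assay, at which 1 of the 3 values shown sits, so its steps are floors rather than exact sizes: an at least 7.4-fold lower number from compound 1 to compound 2 (0.87 log units; beyond the scatter) and an at least 330-fold lower number from compound 1 to compound 3 (2.52 log units; beyond the scatter).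

Compound 4, `Cc1ccccc1Nc1nc2nonc2nc1Nc1ccccc1F`, has not yet been measured. (2-methylphenyl in place of 2,4-difluorophenyl on a nitrogen on an aromatic ring). Within the data shown here, no measured step exchanges one aromatic ring for another; the nearest, the step from compound 2 to compound 3, swaps a saturated ring for an aromatic one, a change of a different kind from the present one, which keeps the aromatic ring and alters only its substituents. The earlier steps shown here therefore set no firm size here. In this assay compound 4 is expected to move only moderately from compound 3, most likely toward a somewhat higher number, with a 2.0-fold higher number from compound 3 to compound 4 (0.30 log units; within the scatter) as the expected step. Compound 4 is estimated at 600 nM, in a range from 150 nM to 2500 nM.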

Compound 4, half-maximal effective concentration: 1100 nM
Estimate against measurement, compound 4: 1.8-fold (0.26 log units) below; low and high end bracket the measured number.
By their numbers in this assay, from the lowest: compound 3; then compound 4; then compound 2. At a limit, above all of these: compound 1.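

Within this assay, keeping an aromatic ring at this place does not fix the number, as a 3.7-fold higher number from compound 3 to compound 4 (0.56 log units; beyond the scatter) shows: the substituents on that ring matter as well, not only whether the ring is aromatic. Even so, 2-methylphenyl still compares well with the saturated ring, with a 12-fold lower number from compound 2 to compound 4 (1.09 log units; beyond the scatter), so compound 3 and compound 4, the two compounds with an aromatic ring here, both lie below the cyclohexyl compound 2. Compound 1 reaches only a limit, so an at least 90-fold lower number from compound 1 to compound 4 (1.95 log units; beyond the scatter) is a floor and not an exact size: the limit of > 100000 nM in this assay, at which 1 of the 4 values shown sits.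

This single exchange removes two fluorines and adds a methyl in one move, and the compounds shown do not separate the share of each in the step. A plain phenyl, a 2-chlorophenyl or a pyridine ring at this place would be needed to show which substituents on the ring shift the number, and whether any of them reaches lower than compound 3.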